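Working notes: the step from compound 3 to compound 4

A few compounds are considered here, and "the series" means these few. Any claim that something is new, unique, unknown or untested is made for them only; others in the source may bear on it.

Measured values, each one a limit and not a number:
compound 1 `Cc1ccc(-c2c3c(nc(C)c2C(OC(C)(C)C)C(=O)O)CCN(CCCC2CCCC2)C3)cc1`: > 40000 nM
compound 2 `Cc1ccc(-c2c3c(nc(C)c2[C@H](OC(C)(C)C)C(=O)O)CCN(CCCc2ccccc2)C3)cc1`: > 40000 nM
compound 3 `Cc1ccc(-c2c3c(nc(C)c2[C@H](OC(C)(C)C)C(=O)O)CCN(C(=O)OCc2ccccc2)C3)cc1`: > 40000 nM

All three were tested in an ADME assay on MT2 cells (Homo sapiens) for cytotoxicity, read by XTT assay, with a stated time of 4 days; a higher number here means that more compound is tolerated, a lower number that less compound is tolerated. Compound 3 stands at > 40000 nM, which is a limit of this assay. It has no number that ranks it, and the series as a whole shows (the limit of > 40000 nM in this assay, at which 3 of the 3 values shown sit).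

The next compound is compound 4 `Cc1ccc(-c2c3c(nc(C)c2[C@H](OC(C)(C)C)C(=O)O)CCN(c2ccccc2)C3)cc1`, with one change on the shared core: phenyl in place of benzyloxycarbonyl on an amine nitrogen in a ring. For the measured compounds named here, the one measured step at this place on an amine nitrogen in a ring is a step that the two limits leave unreadable from compound 2 to compound 3. The data therefore give no measured size for a change at this place, and no step beyond the scatter can be expected in either direction. This expectation rests on compound 3, whose value of > 40000 nM is a limit. The expected step is a number no higher from compound 3 to compound 4 (the limit leaves the size open). The result most likely to be expected in this assay is another limit. For compound 4 the estimated value is 40000 nM, with an expected range of 15000 nM to 80000 nM.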

Compound 4, half-maximal cytotoxic concentration: > 40000 nM
Compound 4 was reported as a limit (the forecaster's own chance of this, stated with the estimate: 80%); the middle value sits exactly at the limit.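

Compound 2, compound 3 and compound 4 each give only a limit in this assay, and no new step can be read among them: the limit of > 40000 nM in this assay, at which 4 of the 4 values shown sit.

The compounds shown leave open whether any group on an amine nitrogen in a ring changes the concentration tolerated.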